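Amide-side variation in one antiproliferative series

The source may report more compounds than this note shows. Statements on the series, on what has been measured and on what is new or still open speak of the compounds shown alone.

Measured so far:
compound 1 `CCn1c(C(=O)NCCN(C)C)ccc1C(CC)(CC)c1ccc(OCCC(O)(CC)CC)c(C)c1` — 870 nM
compound 2 `CCn1c(C(=O)N(C)CC(=O)O)ccc1C(CC)(CC)c1ccc(OCCC(O)(CC)CC)c(C)c1` — 2250 nM
compound 3 `CCn1c(C(=O)NC(CC(=O)O)C(=O)OC)ccc1C(CC)(CC)c1ccc(OCCC(O)(CC)CC)c(C)c1` — 11200 nM

In a functional assay on PC-3 cells (Homo sapiens) for antiproliferative activity, read by MTT assay, with a stated time of 48 h (a lower number here means a stronger inhibitor, a higher number a weaker inhibitor), compound 1 gives the lowest number of the three. Both measured steps away from it run upward: a 2.6-fold higher number from compound 1 to compound 2 (0.41 log units; beyond the scatter); a 13-fold higher number from compound 1 to compound 3 (1.11 log units; beyond the scatter). Compound 4 `CCn1c(C(=O)NC(C)CO)ccc1C(CC)(CC)c1ccc(OCCC(O)(CC)CC)c(C)c1` is not yet measured. Its change from compound 1 is 1-(hydroxymethyl)ethyl in place of 2-(dimethylamino)ethyl on an amide-type nitrogen. Neither measured step tests a hydroxyl-bearing substituent, so the bearing is indirect; the smaller swap on the amide nitrogen (compound 1 to compound 2) gave only a modest rise, the bulkier one (compound 1 to compound 3) a large one. The change to compound 4 is small and keeps one acceptor, so a modest weakening is expected, within the range seen. Compound 4 is expected at 1600 nM, between 600 nM and 4500 nM. That estimate means a 1.8-fold higher number from compound 1 to compound 4 (0.26 log units; within the scatter).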

Compound 4, half-maximal inhibitory concentration: 7870 nM
Compound 4: middle estimate off by 4.9-fold (0.69 log units), on the low side; measured number outside the range, above it.
By their numbers in this assay, from the lowest: compound 1; then compound 2; then compounds 4 and 3 (each within the scatter of the next).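

In this assay the amide-type nitrogen tolerates 1-(hydroxymethyl)ethyl poorly, with a 9.0-fold higher number from compound 1 to compound 4 (0.96 log units; beyond the scatter) even though this group has fewer heavy atoms than 2-(dimethylamino)ethyl. Group size alone does not set the number: the series shows a 1.4-fold lower number from compound 3 to compound 4 (0.15 log units; within the scatter) despite the far larger group of compound 3, and a 3.5-fold higher number from compound 2 to compound 4 (0.54 log units; beyond the scatter) against the carboxymethyl group. Nothing available gives a reason for these steps.

From the compounds shown here alone, whether the dimethylamino nitrogen itself or the chain carrying it matters remains open. A 3-(dimethylamino)propyl chain or a 2-(diethylamino)ethyl chain on the same nitrogen would help separate the two.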